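This account rests on a few compounds, and the source may have more. Where it says the series, first, only, none or still open, it means among the compounds named here.

Measured so far in an ADME assay on cells (Hepatocyte, Mus musculus) for metabolic stability; on this read-out lower numbers stand for a shorter-lived compound and higher numbers for a longer-lived compound:
compound 1, `O=C(OC1CCC(CN2CCN(c3cc(=O)c4cc(C(F)(F)F)cc([N+](=O)[O-])c4s3)CC2)CC1)c1ccco1`, gives < 0.075 h, which is a limit of this assay rather than a number.
compound 2, `O=C(OC1CCC(CN2CCN(c3cc(=O)c4cc(C(F)(F)F)cc([N+](=O)[O-])c4s3)CC2)CC1)c1cccs1`, gives 0.0867 h.
compound 3, `O=C(OC1CCC(CN2CCN(c3cc(=O)c4cc(C(F)(F)F)cc([N+](=O)[O-])c4s3)CC2)CC1)c1ccncc1`, gives 0.0817 h.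

Compound 3 holds the lower of the two numbers shown in this assay. Its nearest neighbour is compound 2, with a 1.1-fold lower number from compound 2 to compound 3 (0.03 log units; within the scatter), a gap within the scatter. Against compound 1 only a floor can be stated, an at least 1.0-fold higher number from compound 1 to compound 3 (0.03 log units; that floor lies within the scatter), since that compound sits at the limit of < 0.075 h in this assay, at which 1 of the 3 values shown sits.

Compound 4, `O=C(OC1CCC(CN2CCN(c3cc(=O)c4cc(C(F)(F)F)cc([N+](=O)[O-])c4s3)CC2)CC1)c1ccc(C(F)(F)F)cc1`, is the next member of the series. Its change from compound 3 is 4-(trifluoromethyl)phenyl in place of pyridin-4-yl on a carbonyl carbon. For the measured compounds named here, the steps that bear on it are the three swaps of the aryl group on the carbonyl carbon already measured: an at least 1.1-fold higher number from compound 1 to compound 2 (0.06 log units; that floor lies within the scatter), an at least 1.0-fold higher number from compound 1 to compound 3 (0.03 log units; that floor lies within the scatter) and a 1.1-fold lower number from compound 2 to compound 3 (0.03 log units; within the scatter). None of these lies beyond the scatter, and two of them are only floors set by the limit of compound 1. The change in compound 4 is of the same kind, so the expectation for this assay is no step beyond the scatter, a 1.0-fold higher number from compound 3 to compound 4 (0.02 log units; within the scatter). Compound 4 is therefore estimated at 0.085 h in this assay, with a range from 0.04 h to 0.2 h.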

Compound 4, half-life: 0.278 h
Estimate against measurement, compound 4: 3.3-fold (0.51 log units) below; measured number outside the range, above it.
By their numbers in this assay, from the lowest: compounds 3 and 2 (each within the scatter of the next); then compound 4. At a limit, below all of these: compound 1.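

On this carbonyl carbon, the swaps among furan-2-yl, thiophen-2-yl and pyridin-4-yl had shown no step beyond the scatter in this assay, so the position looked flat, but 4-(trifluoromethyl)phenyl moves the half-life, with compound 4 at 0.278 h (a 3.4-fold higher number from compound 3 to compound 4 (0.53 log units; beyond the scatter) and a 3.2-fold higher number from compound 2 to compound 4 (0.51 log units; beyond the scatter)). The comparison with the furan-2-yl group gives a floor that also lies beyond the scatter (an at least 3.7-fold higher number from compound 1 to compound 4 (0.56 log units; beyond the scatter)), so all three aryl groups shown on this carbonyl carbon fall short of 4-(trifluoromethyl)phenyl, and the position does respond to the aryl group. Compound 1 holds a limit of the assay, not a number: the limit of < 0.075 h in this assay, at which 1 of the 4 values shown sits.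

The compounds shown do not separate the trifluoromethyl group from the carbon-only ring that carries it, and an unsubstituted phenyl group would be needed to tell the two apart, while a chloro or methoxy group in the same place would show whether trifluoromethyl itself matters. Even compound 4 remains short-lived on this read-out, and whether changes elsewhere on the shared core, such as replacing the nitro group with a nitrile, would add to this step also stays open.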